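Chloro Substitution on a Fused Bicyclic Core in MCF7 Cells

A few compounds are considered here, and "the series" means these few. Any claim that something is new, unique, unknown or untested is made for them only; others in the source may bear on it.

Measured compounds:
compound 1 `Clc1ncnc2c1ncn2CC1CSc2ccccc2O1` gives 9240 nM
compound 2 `Clc1nc(Cl)c2ncn(CC3CSc4ccccc4O3)c2n1` gives 2750 nM
compound 3 `Clc1ncnc2c1ncn2CC1COc2ccccc2O1` gives 18800 nM

These three compounds were tested in a functional assay on MCF7 cells (Homo sapiens) for antiproliferative activity, read by colorimetric assay and sulforhodamine B assay, with a stated time of 3 days; on this read-out lower numbers stand for stronger inhibition and higher numbers for weaker inhibition. Compound 1 and compound 2 differ by one change, (chloro in place of hydrogen on an aromatic carbon), and this change made a 3.4-fold lower number from compound 1 to compound 2 (0.53 log units; beyond the scatter). Compound 3 carries a different core; the difference between the core of compound 1 and the core of compound 3 is not broken down here. Compound 3 gives the highest number of the three, and its value sits furthest from that of compound 2.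

Compound 4 `Clc1nc(Cl)c2ncn(CC3COc4ccccc4O3)c2n1` has not yet been measured in this assay. It differs from compound 3 by chloro in place of hydrogen on an aromatic carbon, which is the same change as that from compound 1 to compound 2, at the same place on the core. Because the step of a 3.4-fold lower number from compound 1 to compound 2 (0.53 log units; beyond the scatter) was a modest one beyond the scatter, a step of similar size is expected here, that is a 3.4-fold lower number from compound 3 to compound 4 (0.53 log units; beyond the scatter). On that basis compound 4 is estimated at 5500 nM, with the likely range running from 2500 nM to 12000 nM.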

Compound 4, half-maximal inhibitory concentration: 19600 nM
The estimate for compound 4 lay 3.6-fold (0.55 log units) below the measured number; measured number above the stated range.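

On the core of compound 3, chloro in place of hydrogen on an aromatic carbon, between two ring nitrogen atoms, gave a 1.0-fold higher number from compound 3 to compound 4 (0.02 log units; within the scatter) in this assay, so the two compounds cannot be told apart on this read-out. Set beside the earlier step, the same change at the same place did not carry over from one core to the other: the same change on two cores in this assay, a 3.4-fold lower number (0.53 log units; beyond the scatter) from compound 1 to compound 2 and a 1.0-fold higher number (0.02 log units; within the scatter) from compound 3 to compound 4, 3.5-fold (0.54 log units) apart, beyond the scatter of two such steps

This shows that, in this series, the step seen on one core is no safe guide to the step on the other, but two pairs do not show what in the cores lies behind the gap, or how the change would fare on a further core.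

The compounds shown carry only hydrogen or chloro at this place, so it remains open whether an amine, a methoxy group or a longer chain there would also behave differently on the two cores. From the compounds shown here alone, it also remains open whether the gap between the two steps would hold in another cell line.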